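Anilino variation on the shared core: compounds 1 to 3

This account rests on a few compounds, and the source may have more. Where it says the series, first, only, none or still open, it means among the compounds named here.

Measured so far:
compound 1 `COc1cc(/C=C/C(=O)c2sc(Nc3ccc(Cl)cc3)nc2C)cc(OC)c1OC` — 22000 nM
compound 2 `COc1cc(/C=C/C(=O)c2sc(Nc3ccc(Cl)c(Cl)c3)nc2C)cc(OC)c1OC` — > 25000 nM

In a functional assay on NCI-H460 cells (Homo sapiens) for cytotoxicity, read by MTT assay (on this read-out lower numbers stand for stronger inhibition and higher numbers for weaker inhibition), compound 1 gives 22000 nM. For compound 2 the read-out is only a limit of the assay, > 25000 nM, so compound 2 stands at the weak end of what has been measured, with no exact number. The step of an at least 1.1-fold higher number from compound 1 to compound 2 (0.05 log units; that floor lies within the scatter) is therefore only a floor; because the limit of > 25000 nM in this assay, at which 1 of the 2 values shown sits, the true size of that step is not known.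

Compound 3 `COc1cc(/C=C/C(=O)c2sc(Nc3ccccc3)nc2C)cc(OC)c1OC` is the next one to be measured in this assay. Compound 3 differs from compound 2 by phenyl in place of 3,4-dichlorophenyl on a nitrogen on an aromatic ring. For the measured compounds named here, the only measured step bearing on this is the one from compound 1 to compound 2, which went in the opposite sense, adding chloro, and moved the number up by an amount whose floor lies within the scatter. Removing both chlorines is expected to move the number down, if at all, by a similarly small step; the expected step is an at least 1.3-fold lower number from compound 2 to compound 3 (0.14 log units; that floor lies within the scatter), which remains within the scatter. Compound 3 is estimated at 18000 nM, with a range from 7000 nM to 45000 nM.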

Compound 3, half-maximal inhibitory concentration: > 25000 nM
Compound 3 was reported as a limit; the forecaster's own chance of this, stated with the estimate: 35%; at least 1.3-fold (0.14 log units) between middle value and limit.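

In this assay compound 3 is reported only as a limit of the assay, > 25000 nM, the same limit as for compound 2. Removing the remaining chloro from the anilino group of compound 1 gives an at least 1.1-fold higher number from compound 1 to compound 3 (0.05 log units; that floor lies within the scatter), so hydrogen in place of chloro on this aromatic carbon brings no readable gain, and anilino does not bring the number into the measured range. The step from compound 2 to compound 3 cannot be read because both values are limits, and with them the comparison of phenyl with 3,4-dichlorophenyl on this nitrogen: the limit of > 25000 nM in this assay, at which 2 of the 3 values shown sit.

As far as these compounds go, how far compound 2 and compound 3 lie past that limit remains open, and so does any ordering of the three compounds by their number of chloro groups. Also open, from the compounds shown here alone, is whether a different group on this aromatic ring, such as a dimethylamino group or a carboxylic acid, would give a number well inside the range of this read-out.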